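This account rests on a few compounds, and the source may have more. Where it says the series, first, only, none or still open, it means among the compounds named here.

Measured in a physicochemical assay for lipophilicity; a lower number here means a more polar compound, a higher number a more lipophilic compound:

- Compound 1 `CCOC(=O)C1=C(C)NC(=S)NC1c1cn(C(=O)CNc2ccccc2[N+](=O)[O-])c2ccccc12`: 2.88
- Compound 2 `CCOC(=O)C1=C(C)NC(=O)NC1c1cn(C(=O)CNc2ccc([N+](=O)[O-])cc2)c2ccccc12`: 1.48

Of these two numbers, compound 1 holds the higher one. Compound 2 lies well under it, and that gap is beyond the usual scatter of repeated measurements. The two compounds differ in more than one place, however, so their gap cannot be pinned on any single structural feature.

The next compound to be measured is compound 3 `CCOC(=O)C1=C(C)NC(=S)NC1c1cn(C(=O)CNc2ccccc2N)c2ccccc12`. It keeps everything in compound 1 except for one group: amino in place of nitro on an aromatic carbon, ortho to a large group (amino in place of nitro on an aromatic carbon).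

Among the measured compounds shown here, no pair of measured compounds shows this swap, so there is no measured step to lean on. The expectation rests on the structural change alone, and it is for a clear drop in this assay, larger than the scatter. The estimated change is a number 0.88 log units lower from compound 1 to compound 3 (beyond the scatter). For compound 3 the expected value is 2, with an estimated range of 1.5 to 2.5.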

Compound 3, partition coefficient: 2.14
Compound 3: the middle estimate sits 0.14 log units below what was measured; measured number inside the range.
By their numbers in this assay, from the lowest: compound 2; then compound 3; then compound 1.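

Among the compounds shown here, compound 1 and compound 3 differ in one place only, so this is the first change here that can be tied to a single structural feature. In this assay, amino in place of nitro on an aromatic carbon, ortho to a large group, gives a number 0.74 log units lower from compound 1 to compound 3 (beyond the scatter), so this one position alone can move the number by more than the usual scatter. The swap replaces a group of 3 heavy atoms and no hydrogen-bond donors with one of 1 heavy atom and 1 hydrogen-bond donor, but no measurement here shows which of these differences drives the step.

From the compounds shown here alone, this is a single step at a single position, so it remains open whether the same swap would give a similar step at another place on the ring or on the core of compound 2. Going by these compounds, it also remains open where other groups at this position, such as a carboxylic acid, a methoxy group or an acetylated amine, would fall relative to nitro and amino.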